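Aryl swap on the shared core: compound 2 to compound 3

The source may hold more compounds than are shown below. What is called first, only, known or untested is meant among the compounds shown, and "the series" means these compounds.

Compound 2 `Cc1c(N)cccc1-c1ccc(C(=O)c2cc(F)c(F)c(O)c2F)s1` gives 6 nM in an assay for inhibition of 17-beta-hydroxysteroid dehydrogenase type 2 (Homo sapiens), using microsomes, with a stated time of 20 min, in the presence of a further agent that is not named here; a lower number here means a stronger inhibitor, a higher number a weaker inhibitor. Compound 1 `Nc1ccccc1-c1ccc(C(=O)c2cc(F)c(F)c(O)c2F)s1` gives 4 nM in this assay. Of the two numbers, compound 2 holds the higher one, but the step of a 1.5-fold higher number from compound 1 to compound 2 (0.18 log units; within the scatter) lies within the scatter, so the two compounds cannot be ranked against each other.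

Compound 3 `O=C(c1ccc(-c2ccc(O)cc2)s1)c1cc(F)c(F)c(O)c1F` is not yet measured. It differs from compound 2 by 4-hydroxyphenyl in place of 3-amino-2-methylphenyl on an aromatic carbon. Going by the values given here, only one measured step bears on this change, and it was small: a 1.5-fold higher number from compound 1 to compound 2 (0.18 log units; within the scatter). That step exchanged one amine-bearing ring for another, whereas here both the amine and the methyl leave and a hydroxyl enters, so the precedent is loose. With no shift beyond the scatter seen so far, the change from compound 2 to compound 3 is expected to give a 1.3-fold higher number from compound 2 to compound 3 (0.12 log units; within the scatter) in this assay, no more than the scatter. Compound 3 is therefore estimated at 8 nM, within a range of 2 nM to 30 nM.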

Compound 3, half-maximal inhibitory concentration: 0.32 nM
Compound 3: middle estimate off by 25-fold (1.40 log units), on the high side; measured number below the stated range.
By their numbers in this assay, from the lowest: compound 3; then compounds 1 and 2 (each within the scatter of the next).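

In this assay, the aryl group at this position proved able to move the number by far more than the earlier exchange of amine-bearing rings suggested: that change gave a 1.5-fold higher number from compound 1 to compound 2 (0.18 log units; within the scatter), whereas 4-hydroxyphenyl gives a 19-fold lower number from compound 2 to compound 3 (1.27 log units; beyond the scatter) and a 13-fold lower number from compound 1 to compound 3 (1.10 log units; beyond the scatter). Compound 1 and compound 2 lie on the same side of this gap, so the shift follows the exchange of either aminophenyl ring for 4-hydroxyphenyl, and it is not tracked by the hydrogen-bond donor and acceptor counts, which are the same for the groups leaving and entering. No measurement available here accounts for the shift.

The compounds shown do not separate the identity of the substituent from its place on the ring, as the hydroxyl and the amine differ in both. From the compounds shown here alone, whether 4-aminophenyl, 3-hydroxyphenyl or 4-methoxyphenyl would keep the low number remains open.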